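The source may report more compounds than this note shows. Statements on the series, on what has been measured and on what is new or still open speak of the compounds shown alone.

Three carbamates share one core and differ only in the aryl group attached through the oxygen on a saturated carbon. Compound 1 `CCC(COc1ccccc1)OC(=O)NCc1ccccc1` carries a plain phenyl there. In an assay for inhibition of zeta-carotene desaturase, chloroplastic/chromoplastic (Capsicum annuum), using a Dixon plot, with a stated time of 8 h (a higher number here means a weaker inhibitor, a lower number a stronger inhibitor), compound 1 gives > 100000 nM, which is a limit of the assay and not a number. Compound 2 `CCC(COc1ccccc1Cl)OC(=O)NCc1ccccc1` has a chloro in place of hydrogen on an aromatic carbon. In this assay compound 2 gives > 100000 nM, again a limit rather than a number. Compound 3 `CCC(COc1cccc(Br)c1)OC(=O)NCc1ccccc1` has a bromo in place of hydrogen on an aromatic carbon. In this assay compound 3 gives > 100000 nM, also a limit. Because all three sit at the limit of > 100000 nM in this assay, at which 3 of the 3 values shown sit, the steps a step that the two limits leave unreadable from compound 1 to compound 2, a step that the two limits leave unreadable from compound 1 to compound 3 and a step that the two limits leave unreadable from compound 2 to compound 3 cannot be read. Compound 2 thus stands at the limit, with no number of its own.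

Compound 4 `CCC(COc1cccc(C#N)c1)OC(=O)NCc1ccccc1` is not yet measured. It differs from compound 2 by 3-cyanophenyl in place of 2-chlorophenyl on an oxygen on a saturated carbon. The measured steps that bear on this change are the three unreadable ones: swapping hydrogen for chloro or bromo, or chloro for bromo, left every compound at the limit. The step expected in this assay, a step that the limit leaves unreadable from compound 2 to compound 4, is therefore none that can be seen, and compound 4 is expected most likely to remain at the limit as well. The estimate for compound 4 is 150000 nM, within a range from 50000 nM to 500000 nM.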

Compound 4, half-maximal inhibitory concentration: > 100000 nM
Compound 4 gave a limit, no number; the forecaster's own chance of this, stated with the estimate: 85%; the middle value is on the limit's open side.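

In this assay compound 4 gives > 100000 nM, which is a limit of the assay and not a number. Its steps from compound 1, compound 2 and compound 3 therefore cannot be read: the limit of > 100000 nM in this assay, at which 4 of the 4 values shown sit. The compounds shown leave open how these four compare with one another and whether any aryl group on the shared core gives a readable number in this assay.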